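Fluorine on the allyl arm of an amide series

The compounds below may be only part of what the source reports. "The series", "measured", "known", "first", "only" and "open" are said of these compounds alone.

Three compounds share one core and differ only on the chain carbon bound to the amide-type nitrogen. Compound 1 `C#CCN(CC=C)C(=O)[C@@]1(c2ccsc2)C[C@H]1CN` reaches only the limit of > 10000 nM in an assay on HEK293 cells for inhibition of sodium-dependent dopamine transporter (Homo sapiens); a higher number here means a weaker inhibitor, a lower number a stronger inhibitor. Compound 2 `C=CCN(CC=C)C(=O)[C@@]1(c2ccsc2)C[C@H]1CN` gives 8300 nM. Compound 3 `C=CCN(CCOC)C(=O)[C@@]1(c2ccsc2)C[C@H]1CN` again shows only the limit of > 10000 nM, so its position is known just as a limit, as the limit of > 10000 nM in this assay, at which 2 of the 3 values shown sit, records. Compound 4 `C=C(F)CN(CCOC)C(=O)[C@@]1(c2ccsc2)C[C@H]1CN` differs from compound 3 by fluoro in place of hydrogen on a double-bonded chain carbon bound to a saturated chain carbon. Among the compounds with values here, no measured step changes that double-bonded carbon; the steps of an at least 1.2-fold lower number from compound 1 to compound 2 (0.08 log units; that floor lies within the scatter) and an at least 1.2-fold higher number from compound 2 to compound 3 (0.08 log units; that floor lies within the scatter) concern other groups and stay within scatter. Compound 4 is therefore expected to show little change, a step that the limit leaves unreadable from compound 3 to compound 4, and is estimated at 12000 nM, ranging from 4000 nM to 40000 nM, most likely again only a limit.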

Compound 4, half-maximal inhibitory concentration: > 10000 nM
Compound 4: no number, only a limit; the forecaster's own chance of this, stated with the estimate: 70%; the middle value is on the limit's open side.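

Within the data shown here, compound 4 ends at a limit, as compound 3 does, so no step between the two can be read: the limit of > 10000 nM in this assay, at which 3 of the 4 values shown sit. From the compounds shown here alone, whether fluoro in place of hydrogen on the double-bonded carbon changes inhibition at all stays open.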